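A few compounds are considered here, and "the series" means these few. Any claim that something is new, unique, unknown or untested is made for them only; others in the source may bear on it.

Measured compounds in an ADME assay on the whole organism with Oryza sativa as the target, tested at 0.1 uM; on this read-out higher numbers stand for a weaker effect at the one concentration tested and lower numbers for a stronger effect:
compound 1, `Cc1ccccc1NC(=O)N[C@H](C)c1ccccc1`: 100%
compound 2, `Cc1ccccc1NC(=O)N[C@@H](C)c1ccccc1`: 100%
compound 3, `CCCCCCc1ccc(NC(=O)N[C@H](C)c2ccccc2)cc1`: 100%

Compound 1 stands level with compounds 2 and 3 at the digits shown; its nearest neighbour is compound 2 and its furthest is compound 3, and neither gap goes beyond the scatter. Going by the values given here, the one step measured between structures that differ in a single place, no change at the digits printed from compound 1 to compound 2 (within the scatter), runs between two compounds whose only difference is the fact that compounds 1 and 2 differ only in the configuration as drawn.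

Compound 4, `COc1ccccc1NC(=O)N[C@H](C)c1ccccc1`, is yet to be measured. It differs from compound 1 by methoxy in place of methyl on an aromatic carbon. Among the compounds with values here, no measured step touches this kind of change; the step from compound 1 to compound 2 bears on it only in showing that a small alteration of the shared core left the read-out unmoved. The spread of the measured values is nil, so no movement in this assay beyond the scatter is expected, and the step is expected to be no change at the digits printed from compound 1 to compound 4 (within the scatter). Compound 4 is therefore estimated at 100%, in the range 85% to 100%.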

Compound 4, a percentage reported as activity, at one concentration (the size of the read-out at that concentration, not a potency): 100%
Compound 4: the middle estimate sits on the measured number at the digits printed, and the stated range covers the measured number.
By their numbers in this assay, from the lowest: compounds 1, 2, 3 and 4 (each within the scatter of the next).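

In this assay, going by these compounds alone, this is the first measured change of a group on the aromatic carbon ortho to a large group, and it gives no change at the digits printed from compound 1 to compound 4 (within the scatter). The exchange of methyl for methoxy brings in an oxygen and one hydrogen-bond acceptor at this position, yet the read-out does not move beyond the scatter. Nothing known about these compounds bears on why this exchange left the read-out unmoved.

Within the data shown here, compounds 1 and 4 show only that these two small groups read alike at the single concentration tested, so how far this position tolerates change remains unsettled. Going by these compounds, whether an amine, a carboxylic acid or a longer chain such as ethoxy on this carbon would shift the read-out stays open.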